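Series notes: from compound 3 to compound 4

The source may hold more compounds than are shown below. What is called first, only, known or untested is meant among the compounds shown, and "the series" means these compounds.

Measured so far in an assay on microsomes from brain for inhibition of Fatty-acid amide hydrolase 1 (Rattus norvegicus), read by fluorescence and HPLC, with a stated time of 60 min; on this read-out higher numbers stand for weaker inhibition and lower numbers for stronger inhibition:
compound 1, `CCCCCCCCc1ccc(OCC(=O)Cn2nnc(-c3ccc(Cl)cc3)n2)cc1`: 35 nM
compound 2, `CCCCCCCCc1ccc(OCC(=O)Cn2nnc(-c3ccc(C(=O)OC)cc3)n2)cc1`: 29 nM
compound 3, `CCCCCCCCc1ccc(OCC(=O)Cn2nnnc2-c2ccc(Cl)cc2)cc1`: 130 nM

Compound 3 holds the highest of the three numbers; the nearest is compound 1 and the furthest is compound 2, both beyond the scatter, so compound 3 is the weakest inhibitor of the three. Compound 1 and compound 2 share one core, compound 3 another, and the step between compound 1 and compound 2 is the only one measured within a single core: a 1.2-fold lower number from compound 1 to compound 2 (0.08 log units; within the scatter).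

Compound 4, `CCCCCCCCc1ccc(OCC(=O)Cn2nnnc2-c2cccc(C(=O)O)c2)cc1`, is not yet measured. It differs from compound 3 in one place: 3-carboxyphenyl in place of 4-chlorophenyl on an aromatic carbon.

What bears on it is the step from compound 1 to compound 2, a replacement of chloro by a carbonyl-bearing group that stayed within the scatter. Here the entering group is a carboxylic acid, the ring is attached through a different position, and the core is that of compound 3, so the carry-over is loose. The expectation is still for no step beyond the scatter, with wide bounds: a 1.2-fold higher number from compound 3 to compound 4 (0.06 log units; within the scatter). Compound 4 is thus estimated at 150 nM in this assay, in the range 50 nM to 500 nM.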

Compound 4, half-maximal inhibitory concentration: 1800 nM
Estimate against measurement, compound 4: 12-fold (1.08 log units) below; measured number outside the range, above it.
By their numbers in this assay, from the lowest: compounds 2 and 1 (each within the scatter of the next); then compound 3; then compound 4.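

In this assay, the exchange at the aromatic carbon of the five-membered ring gives a 14-fold higher number from compound 3 to compound 4 (1.14 log units; beyond the scatter), so this place on the core of compound 3 is sensitive to what the attached phenyl ring carries. Among these compounds, the only earlier step within one core, a 1.2-fold lower number from compound 1 to compound 2 (0.08 log units; within the scatter), lay within the scatter, and its replacement of chloro by methoxycarbonyl therefore gives no guide to the exchange of 4-chlorophenyl for 3-carboxyphenyl. This exchange alters both the substituent and its place on the phenyl ring, so the large step belongs to the exchange as a whole and cannot be divided between the two, and nothing measured here bears on what lies behind it.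

The compounds shown leave open whether a methyl ester, a primary amide or a hydroxymethyl group in place of the carboxylic acid on the same phenyl ring would stay close to compound 3 or follow compound 4. Also open, on these data alone, is whether a carboxylic acid on the core of compound 1 would bring a step of similar size, or whether the sensitivity seen here is confined to the core of compound 3.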